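Amide substituent change on the isoxazole carboxamide series

This account rests on a few compounds, and the source may have more. Where it says the series, first, only, none or still open, it means among the compounds named here.

Measured so far:
compound 1 `O=C(N[C@H]1CCCC[C@H]1O)c1noc(-c2ccc(C(F)(F)F)cc2)c1Cl` — 65 nM
compound 2 `O=C(NC1CCCC1)c1noc(-c2ccc(OC(F)(F)F)cc2)c1Br` — 1250 nM

In a functional assay on CHO cells for antagonist activity at transient receptor potential cation channel subfamily V member 1 (Homo sapiens), read by fluorescence and calcium flux (on this read-out higher numbers stand for weaker inhibition and lower numbers for stronger inhibition), compound 1 gives 65 nM. Compound 2 gives 1250 nM in this assay, and the two structures differ in more than one place, so the gap between them is noted only as a gap: compound 1 holds the lower number of the two, by a margin beyond the scatter.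

Compound 3 `COCCCNC(=O)c1noc(-c2ccc(C(F)(F)F)cc2)c1Cl` has not been measured. Against compound 1 the change is 3-methoxypropyl in place of 2-hydroxycyclohexyl on an amide-type nitrogen. A hydroxyl-bearing ring gives way to an open chain that carries no donor. Among the measured compounds shown here, no measured pair isolates this change, so the step is an expectation only: compound 3 is expected to come out somewhat weaker than compound 1, with a step of a 3.8-fold higher number from compound 1 to compound 3 (0.59 log units; beyond the scatter) that may lie only modestly beyond the scatter. Compound 3 is therefore estimated at 250 nM, within 80 nM to 900 nM.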

Compound 3, half-maximal inhibitory concentration: 2210 nM
Beside the measured number, compound 3's estimate is 8.8-fold (0.95 log units) below it, and the stated range ends below it.
By their numbers in this assay, from the lowest: compound 1; then compounds 2 and 3 (each within the scatter of the next).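

On the shared core, the substituent on the amide-type nitrogen is not a neutral place: in this assay, 3-methoxypropyl in place of 2-hydroxycyclohexyl gives a 34-fold higher number from compound 1 to compound 3 (1.53 log units; beyond the scatter), a large step and the first one in the series read across a single change. The change removes the carbon ring, the hydrogen-bond donor and the defined stereocentres together, while the hydrogen-bond acceptor count stays the same, so this one step cannot assign the loss to any one of these features. Nothing available explains the size of the step.

Still open, as far as these compounds go, is which feature carries the difference: plain cyclohexyl and 3-hydroxypropyl on the same nitrogen would separate the ring from the hydroxyl. The other stereoisomers of 2-hydroxycyclohexyl would test the role of its stereocentres.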